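The source may report more compounds than this note shows. Statements on the series, on what has been measured and on what is new or still open speak of the compounds shown alone.

For the measured compounds named here, in a functional assay on CHO cells for agonist activity at Free fatty acid receptor 2 (Homo sapiens), read by cAMP accumulation (on this read-out higher numbers stand for larger maximal responses and lower numbers for smaller maximal responses), compound 3 `CC(C)[C@H](C(=O)Nc1nncs1)c1ccc(Cl)cc1` gives 115%, the only number that the three measured compounds yield. Compound 1 `CC(C)[C@H](C(=O)NC(C)(C)C)c1ccc(Cl)cc1` is reported only as a limit of the assay, < 30%. Compound 2 `CC(C)[C@H](C(=O)Nc1ccccc1)c1ccc(Cl)cc1` likewise is reported as a limit, < 30%. Two of the three values thus sit at the same limit (the limit of < 30% in this assay, at which 2 of the 3 values shown sit), and the steps toward compound 3 read as follows: a number at least 85 percentage points higher from compound 1 to compound 3 (beyond the scatter), a number at least 85 percentage points higher from compound 2 to compound 3 (beyond the scatter), while a step that the two limits leave unreadable from compound 1 to compound 2. Both large steps arrive at the same group, 1,3,4-thiadiazol-2-yl on the amide-type nitrogen, and each leaves behind a group that is not a five-membered aromatic ring.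

Compound 4 `Cc1csc(NC(=O)[C@H](c2ccc(Cl)cc2)C(C)C)n1` differs from compound 3 by 4-methyl-1,3-thiazol-2-yl in place of 1,3,4-thiadiazol-2-yl on an amide-type nitrogen. The change keeps a five-membered aromatic ring with one sulfur on the amide-type nitrogen and adds a methyl. Going by the values given here, the two measured steps bear on it only indirectly: they show that a five-membered heteroaromatic ring at this position can carry a full response, but no measured pair compares one such ring with another, so the change is largely untested. The step of a number 20 percentage points lower from compound 3 to compound 4 (beyond the scatter) is expected to remain within the scatter or to point modestly downward. Compound 4 is estimated at 95%, with a range from 50% to 130%.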

Compound 4, largest response reached (reported as efficacy), in percent of the reference or control that the assay uses: 87%
Beside the measured number, compound 4's estimate is 8 percentage points above it; measured number inside the range.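

In this assay, the large gain over tert-butyl and phenyl on the amide-type nitrogen is not confined to 1,3,4-thiadiazol-2-yl, as 4-methyl-1,3-thiazol-2-yl also gives a number at least 57 percentage points higher from compound 1 to compound 4 (beyond the scatter) and a number at least 57 percentage points higher from compound 2 to compound 4 (beyond the scatter). Two five-membered aromatic rings can now be compared at this position, and they do not read the same: 4-methyl-1,3-thiazol-2-yl in place of 1,3,4-thiadiazol-2-yl gives a number 28 percentage points lower from compound 3 to compound 4 (beyond the scatter), a modest step beside the two large ones. Those two large steps start from limits of the assay and therefore fix only a minimum size, while the step between compound 1 and compound 2 remains unreadable: the limit of < 30% in this assay, at which 2 of the 4 values shown sit.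

The change from 1,3,4-thiadiazol-2-yl to 4-methyl-1,3-thiazol-2-yl alters the ring atoms and adds a methyl in a single step, and the compounds shown do not tell which of the two goes with the lower response; the plain 1,3-thiazol-2-yl group would stand between them. They also leave open how the response would change with an amine or a carboxylic acid in place of that methyl.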